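This account rests on a few compounds, and the source may have more. Where it says the series, first, only, none or still open, it means among the compounds named here.

The compounds share the core of compound 1, `Cc1ccc(S(=O)(=O)Nc2ccc3oc(-c4ccccc4)nc3c2)cc1`. In an assay on isolated protein for inhibition of malate dehydrogenase, mitochondrial (Sus scrofa), with stated times of 45 min and 30 min (a lower number here means a stronger inhibitor, a higher number a weaker inhibitor), compound 1 gives > 63000 nM, which is a limit of the assay and not a number, so its standing among the values shown is known only as that limit. Compound 2, `O=S(=O)(Nc1ccc(-c2nc3ccccc3o2)cc1)c1cccc(O)c1`, is a close relative. In this assay compound 2 gives > 63000 nM, again a limit. Compound 3, `O=S(=O)(Nc1ccc(-c2nc3ccccc3o2)cc1)c1cccc(Cl)c1`, has chloro in place of hydroxy on an aromatic carbon. In this assay compound 3 gives > 63000 nM, also a limit. The step that the two limits leave unreadable from compound 2 to compound 3 therefore cannot be read, and the limit of > 63000 nM in this assay, at which 3 of the 3 values shown sit, is the whole of the evidence. Compound 4, `O=S(=O)(Nc1ccc2oc(-c3ccccc3)nc2c1)c1ccccc1F`, differs from compound 1 by 2-fluorophenyl in place of 4-methylphenyl on a sulfonyl sulfur. Among the measured compounds shown here, no measured step bears on this change, and every value shown is a limit, so no step beyond the scatter is expected. Compound 4 is expected to give 100000 nM, within 40000 nM to 300000 nM, most likely reported once more as a limit. The expected step that the limit leaves unreadable from compound 1 to compound 4 is none beyond the scatter.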

Compound 4, half-maximal inhibitory concentration: > 63000 nM
Compound 4: no number, only a limit (the forecaster's own chance of this, stated with the estimate: 85%); the middle value lies beyond the limit too.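

Compound 4, like compound 1, gives only a limit, so the step between them cannot be read, and what stands is this: the limit of > 63000 nM in this assay, at which 4 of the 4 values shown sit. In this assay the compounds shown leave open which change to the shared core, if any, would give a measurable value.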